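Varying the group on the ring nitrogen of the shared core

The compounds below may be only part of what the source reports. "The series", "measured", "known", "first", "only" and "open" are said of these compounds alone.

Among the compounds with values here, the three compounds measured so far share one core and differ at the group on an aromatic nitrogen of the five-membered ring of the fused system. Compound 1 `CC(C)c1onc(-c2c(Cl)cccc2Cl)c1COc1ccc(-c2nc3cc(C(=O)O)ccc3n2C)cc1` gives 4410 nM in an assay on HEK-293T cells for antagonist activity at vitamin D3 receptor (Homo sapiens), read by a luciferase reporter, with a stated time of 24 h; on this read-out higher numbers stand for weaker inhibition and lower numbers for stronger inhibition. Compound 2 `CC(C)c1onc(-c2c(Cl)cccc2Cl)c1COc1ccc(-c2nc3ccc(C(=O)O)cc3n2C2CC2)cc1` gives 3200 nM in this assay, and compound 3 `CC(C)c1onc(-c2c(Cl)cccc2Cl)c1COc1ccc(-c2nc3ccc(C(=O)O)cc3n2-c2ccc(F)cc2)cc1` gives 2410 nM. Compound 3 thus carries the lowest of the three numbers, but its gaps to compound 2 and to compound 1 both lie within the scatter, so no order among the three can be claimed.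

Within the data shown here, the only single-place step available is a 1.3-fold lower number from compound 2 to compound 3 (0.12 log units; within the scatter), which shows that swapping one group for another on that nitrogen left the number essentially unchanged.

Compound 4 `CC(=O)C1CCC(Cn2c(-c3ccc(OCc4c(-c5c(Cl)cccc5Cl)noc4C(C)C)cc3)nc3ccc(C(=O)O)cc32)CC1` is not yet measured. It differs from compound 3 by (4-acetylcyclohexyl)methyl in place of 4-fluorophenyl on an aromatic nitrogen. Among the measured compounds shown here, the one measured step that bears on this position was within the scatter, and the values of compounds 1 and 2 point the same way, so a change beyond the scatter is not expected for compound 4, in either direction, with a slight lean toward a lower number given that compound 3 already sits lowest.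

Compound 4 is therefore expected to give about 2000 nM in this assay, within a range from 700 nM to 6000 nM, meaning an expected step of a 1.2-fold lower number from compound 3 to compound 4 (0.08 log units; within the scatter).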

Compound 4, half-maximal inhibitory concentration: > 10000 nM
Compound 4 was reported as a limit (the forecaster's own chance of this, stated with the estimate: 5%); at least 5.0-fold (0.69 log units) between middle value and limit.
By their numbers in this assay, from the lowest: compounds 3, 2 and 1 (each within the scatter of the next). At a limit, above all of these: compound 4.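

In this assay, compound 4 is reported only as a limit, not as a number: the limit of > 10000 nM in this assay, at which 1 of the 4 values shown sits.

The change to (4-acetylcyclohexyl)methyl gives an at least 4.1-fold higher number from compound 3 to compound 4 (0.61 log units; beyond the scatter), and measured against cyclopropyl it gives an at least 3.1-fold higher number from compound 2 to compound 4 (0.49 log units; beyond the scatter). These are the first single-place steps at this aromatic nitrogen that lie beyond the scatter, so the group placed here can matter for this read-out, although the swap of cyclopropyl for 4-fluorophenyl had not shown this.

The entering group differs from 4-fluorophenyl in more than one feature, since it has a non-aromatic ring, a carbonyl in its acetyl group and a carbon link to the nitrogen, and the compounds shown do not separate these features or show how far the value of compound 4 lies past the limit. From the compounds shown here alone, a plain cyclohexylmethyl group without the acetyl, a benzyl group, or a cyclohexyl ring joined directly to the nitrogen would each test one of these features, and the outcome for any of them remains open.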